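Series notes: amine ring swap on the shared core

The source may hold more compounds than are shown below. What is called first, only, known or untested is meant among the compounds shown, and "the series" means these compounds.

Within the data shown here, compound 1 `CN1CCN(c2c(S(=O)(=O)c3ccccc3)cnc3ccccc23)CC1` is one of three compounds measured in an assay on isolated protein for displacement of a labelled ligand from metabotropic glutamate receptor 5 (Homo sapiens), with a stated time of 60 min, tested at 1 uM; on this read-out lower numbers stand for less inhibition and higher numbers for more inhibition at the one concentration tested (going by the name of the read-out). In this assay compound 1 gives 7.7%, the lowest of the three numbers. Among the measured compounds shown here, compound 3 `O=S(=O)(c1ccccc1)c1cnc2ccccc2c1N1CCN(c2ccccc2)CC1` gives 13.5% in this assay, and the only single-place step recorded, a number 5.8 percentage points higher from compound 1 to compound 3 (within the scatter), lies within the scatter. Compound 2 `CC1CCN(c2c(S(=O)(=O)c3cccc(C#N)c3)cnc3cc(F)ccc23)CC1` differs from compound 1 in several places at once. In this assay compound 2 gives 92%, far beyond the scatter from the number of compound 1; no single step accounts for that gap.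

Compound 4 `O=S(=O)(c1ccccc1)c1cnc2ccccc2c1N1CCCC1` has not yet been measured. It differs from compound 1 as follows: pyrrolidin-1-yl in place of 4-methylpiperazin-1-yl on an aromatic carbon. For the measured compounds named here, the only measured step that touches the same part of the shared core is the one from compound 1 to compound 3, which altered the group on the amine nitrogen of the ring and stayed within the scatter. Going by the values given here, no measured pair replaces the ring itself, so there is no step that bears directly on the change to compound 4.

Given that the one related step was within the scatter, no change beyond the scatter is expected in this assay; the estimated step is a number 4.3 percentage points higher from compound 1 to compound 4 (within the scatter). Compound 4 is accordingly expected to give about 12% in this assay, with a range from 0% to 35%.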

Compound 4, a percentage reported as inhibition, at one concentration (the size of the read-out at that concentration, not a potency): 7.1%
Estimate against measurement, compound 4: 4.9 percentage points above; the range from low to high includes it.
By their numbers in this assay, from the lowest: compounds 4, 1 and 3 (each within the scatter of the next); then compound 2.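

The step at this position now covers the ring itself and not only its substituent: in this assay, pyrrolidin-1-yl in place of 4-methylpiperazin-1-yl on the aromatic carbon opposite the ring nitrogen gives a number 0.6 percentage points lower from compound 1 to compound 4 (within the scatter). Taken with a number 5.8 percentage points higher from compound 1 to compound 3 (within the scatter), this means that both single-place changes at this position, one on the amine nitrogen and one to the ring as a whole, stay within the scatter, a statement limited to compounds 1, 3 and 4. Going from a six-membered ring with 2 hetero atoms to a five-membered ring with 1 hetero atom therefore leaves the number of the shared core where it was, and no measurement on hand offers an explanation for that.

From the compounds shown here alone, whether morpholin-4-yl, an open-chain dimethylamino group or a ring carrying a carboxylic acid at this position would also stay within the scatter of compound 1 remains open. Among these compounds, compound 2 gives 92% but differs from the others in several places at once, and no single-place step links it to them, so which of its differences goes with that number is also open.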